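A few compounds are considered here, and "the series" means these few. Any claim that something is new, unique, unknown or untested is made for them only; others in the source may bear on it.

Measured so far, as read in a functional assay on HeLa cells (Homo sapiens) for cytotoxicity, read by MTT assay, with a stated time of 48 h (on this read-out higher numbers stand for weaker inhibition and lower numbers for stronger inhibition), for both entries:
- compound 1 `COc1cc([C@@H]2C[C@]2(CO)C(=O)Nc2ccccc2Cl)cc(OC)c1OC` gives 8100 nM in this series
- compound 2 `COc1cc([C@@H]2C[C@]2(CO)C(=O)NCc2ccc(C)cc2)cc(OC)c1OC` gives 17400 nM in this series

Compound 1 stands lowest of the two numbers, with compound 2 as its nearest neighbour. Still to be measured is compound 3 `COc1cc([C@H]2C[C@]2(CO)C(=O)Nc2ccccc2Cl)cc(OC)c1OC`, and its relation to compound 1 is this: the two compounds have the same atoms and bonds and differ only in configuration as drawn: 1 of 2 stereo elements differ; a stereocentre at a saturated ring carbon is drawn S in compound 1 and R in compound 3 and nothing else changes. Going by the values given here, the only measured step, a 2.1-fold higher number from compound 1 to compound 2 (0.33 log units; beyond the scatter) for 4-methylbenzyl in place of 2-chlorophenyl on an amide-type nitrogen, is modest and concerns a different kind of change. Among the compounds with values here, no measured pair tests configuration, so the data set no direction, and no step beyond the scatter is expected in this assay as a working assumption. The expected change is small (a 1.4-fold higher number from compound 1 to compound 3 (0.13 log units; within the scatter)), and this remains an estimate. The estimated value for compound 3 is 11000 nM with an expected range from 3500 nM to 35000 nM for now.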

Compound 3, half-maximal inhibitory concentration: 45500 nM
Compound 3: middle estimate off by 4.1-fold (0.62 log units), on the low side; measured number outside the range, above it.
By their numbers in this assay, from the lowest: compound 1; then compound 2; then compound 3.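

In this assay, the configuration at the saturated ring carbon is not neutral: drawing it R rather than S gives a 5.6-fold higher number from compound 1 to compound 3 (0.75 log units; beyond the scatter). The S form, compound 1, therefore holds the lower number within this 2-chlorophenyl amide pair, a direction that the earlier comparison, which changed only the group on the amide-type nitrogen, could not supply. The step can be assigned to this one stereocentre alone because nothing else in the structure changes: the fact that compounds 1 and 3 differ only in the configuration as drawn.

From the compounds shown here alone, whether the same direction and a similar size hold with 4-methylbenzyl on the amide-type nitrogen remains open, as does the effect of changing the second stereo element. Also open, going by these compounds, is whether a carboxylic acid in place of the hydroxymethyl group would preserve the difference between the two configurations.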